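A few compounds are considered here, and "the series" means these few. Any claim that something is new, unique, unknown or untested is made for them only; others in the source may bear on it.

Measured in a functional assay on M21 cells (Homo sapiens) for inhibition, read by sulforhodamine B assay, with a stated time of 48 h; a higher number here means a weaker inhibitor of growth, a lower number a stronger inhibitor of growth:
- compound 1 `O=C(CCl)NC(=O)Nc1ccc(C2CCCCC2)cc1`: 900 nM
- compound 2 `O=C(CCl)NC(=O)Nc1ccc(OC2CCCC2)cc1`: 2900 nM
- compound 3 `O=C(CCl)NC(=O)Nc1ccc(OC2CCCCCC2)cc1`: 5000 nM

Compound 3, at 5000 nM, stands with compound 2 at the weak end of this small set, the two being separated by a 1.7-fold higher number from compound 2 to compound 3 (0.24 log units; within the scatter). Compound 1 lies well apart from both, at 900 nM.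

The next compound is compound 4 `O=C(CCl)NC(=O)Nc1ccc(Oc2ccccc2)cc1`, and the change is phenyl in place of cycloheptyl on an oxygen on an aromatic ring.

Among the measured compounds shown here, two measured steps bear on this. For the measured compounds named here, the closer one is a 1.7-fold higher number from compound 2 to compound 3 (0.24 log units; within the scatter), the only measured change of the group on that oxygen, and it stays within the scatter. The other is a 3.2-fold higher number from compound 1 to compound 2 (0.51 log units; beyond the scatter), a modest step that also alters the link to the ring. Going by the values given here, neither step puts an aromatic group on the oxygen, so the data offer no direct precedent for phenyl.

In this assay, a shift beyond the scatter is therefore not expected, with only a slight lean towards a lower number. The estimated step is a 1.7-fold lower number from compound 3 to compound 4 (0.22 log units; within the scatter). The range is kept wide, as the modest step shows how far a change at this place can move the number. For compound 4 the estimated value is 3000 nM, with an expected range of 1100 nM to 8000 nM.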

Compound 4, concentration for 50% growth inhibition: 4200 nM
Compound 4: middle estimate off by 1.4-fold (0.15 log units), on the low side, and the stated range covers the measured number.
By their numbers in this assay, from the lowest: compound 1; then compounds 2, 4 and 3 (each within the scatter of the next).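

In this assay, replacing the saturated ring on the oxygen with an aromatic one leaves the number in place (a 1.2-fold lower number from compound 3 to compound 4 (0.08 log units; within the scatter)) (a 1.4-fold higher number from compound 2 to compound 4 (0.16 log units; within the scatter)), and both steps lie within the scatter. Across compounds 2, 3 and 4, this position therefore tolerates cyclopentyl, cycloheptyl and phenyl on an oxygen on an aromatic ring without a readable difference, and none of the three goes against that. Compound 1, with cyclohexyl directly on the aromatic carbon, remains apart from the phenoxy compound (a 4.7-fold higher number from compound 1 to compound 4 (0.67 log units; beyond the scatter)), a modest step beyond the scatter, and no measurement here explains either this gap or the flat readings among the oxygen-linked groups.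

Open, going by these compounds, is whether the gap follows the oxygen link or the group itself, which cyclohexyloxy and phenyl placed directly on the aromatic carbon would separate. Also open, on these data alone, is whether the flat response on the oxygen extends beyond rings of carbon only, for example to a longer chain on the oxygen, or to an amine or a carboxylic acid carried on the phenyl ring.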